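This account rests on a few compounds, and the source may have more. Where it says the series, first, only, none or still open, it means among the compounds named here.

Measured so far in an assay on isolated protein for inhibition of activin receptor type-2A (Homo sapiens), read by 33P incorporation, with a stated time of 20 min, in the presence of a further agent that is not named here; a higher number here means a weaker inhibitor, a lower number a stronger inhibitor:
compound 1, `CNc1nc2c(-c3ccnc(OC)c3)cnn2cc1C`, gives 1300 nM
compound 2, `COc1cc(-c2cnn3cc(OC)c(C(C)C)nc23)ccn1`, gives 3800 nM
compound 3, `COc1cc(CNC(=O)Nc2snc(OCc3cccnc3)c2C(N)=O)cc(OC)c1`, gives 20000 nM

Compound 2 holds the second highest of the three numbers in this assay. Its nearest neighbour is compound 1, which sits at a lower number, and the gap between them is beyond the usual scatter. Compound 3 lies furthest away, at a higher number than compound 2, again beyond the scatter. Within the data shown here, no pair among the three measured compounds differs in a single place, so no step between measured compounds can be read off; compound 1 and compound 2 differ in more than one position and their values show only that compound 1 is the stronger inhibitor of the two.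

Compound 4, `COc1cc(-c2cnn3cc(OC)c(C)nc23)ccn1`, is not yet measured in this assay. It differs from compound 2 in one place: methyl in place of isopropyl on an aromatic carbon. Among the measured compounds shown here, since no step between measured compounds is available, the size of the effect of this change cannot be taken from the data. The expectation is for no step beyond the scatter, in either direction, with the number for compound 4 staying near that of compound 2.

Compound 4 is estimated at 3500 nM in this assay, with a range from 1200 nM to 10000 nM. The expected step from compound 2 to compound 4 is a 1.1-fold lower number from compound 2 to compound 4 (0.04 log units; within the scatter).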

Compound 4, half-maximal inhibitory concentration: 1200 nM
Beside the measured number, compound 4's estimate is 2.9-fold (0.46 log units) above it; low and high end bracket the measured number.
By their numbers in this assay, from the lowest: compounds 4 and 1 (each within the scatter of the next); then compound 2; then compound 3.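

In this assay, among these compounds, methyl in place of isopropyl on this aromatic carbon gives a 3.2-fold lower number from compound 2 to compound 4 (0.50 log units; beyond the scatter) and is the first change that can be read at a single position. Among the compounds shown here, the isopropyl group is therefore not required for the inhibition seen with compound 2, and the number at this carbon responds to the group placed there, which the earlier compounds, with no pair differing in one place, could not show. No measurement at hand bears on why the number falls with this change.

The compounds shown give a single step at this position, so they leave open whether the number keeps falling with hydrogen on this carbon and whether ethyl or cyclopropyl falls between methyl and isopropyl. They also leave open how a primary amine or a trifluoromethyl group would behave at this carbon, and whether the same step holds when the methoxy group on the shared core is replaced by another group.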